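This account rests on a few compounds, and the source may have more. Where it says the series, first, only, none or still open, it means among the compounds named here.

Compound 1 `c1ccc(-c2nnc(-c3nsc4ccccc34)o2)cc1`: 60%
Compound 2 `Clc1ccc(-c2nnc(-c3nsc4ccccc34)o2)cc1`: 50%

Both compounds were measured in a functional assay on the whole organism for inhibition, with Rattus norvegicus as the target, with a stated time of 2 h, at a dose of 100 mg/kg by the intraperitoneal route; a lower number here means less inhibition, a higher number more inhibition at the dose given (going by the name of the read-out). Among the compounds with values here, compound 2 stands lowest of the two numbers, with compound 1 as its only neighbour; the one measured step, a number 10 percentage points lower from compound 1 to compound 2 (within the scatter), comes from chloro in place of hydrogen on an aromatic carbon and lies within the scatter.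

Compound 3 `CNc1nnc(-c2nsc3ccccc23)o1` has not yet been measured. It differs from compound 2 in one place: methylamino in place of 4-chlorophenyl on an aromatic carbon. Within the data shown here, the single measured step concerns only the chloro substituent and keeps the phenyl ring, so it does not bear on removing that ring altogether. Among the measured compounds shown here, with no step of comparable kind to lean on, the expectation rests on the larger structural change and carries a wide range. Compound 3 is expected to give 40%, between 15% and 65%. This estimate implies a step of a number 10 percentage points lower from compound 2 to compound 3 (within the scatter).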

Compound 3, a percentage reported as inhibition, in the whole organism at one dose (the size of the read-out at that dose, not a potency): 67%
Compound 3: middle estimate off by 27 percentage points, on the low side; measured number outside the range, above it.
By their numbers in this assay, from the lowest: compounds 2, 1 and 3 (each within the scatter of the next, the first and the last beyond it).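

In this assay the aromatic ring on this carbon of the five-membered ring turns out not to be needed for a response of this size: methylamino in place of 4-chlorophenyl, a much smaller group with no ring, raises the number rather than lowering it (a number 17 percentage points higher from compound 2 to compound 3 (beyond the scatter)). Against plain phenyl, the same swap gives no readable change (a number 7 percentage points higher from compound 1 to compound 3 (within the scatter)), so the gain holds only in the comparison with the chlorinated compound. Nothing measured here explains why the smaller group holds up so well.

Still open, going by these compounds, is whether a plain amino group, a dimethylamino group or a longer chain such as butylamino on this carbon would keep the response. On these data alone, each compound is also seen at a single dose, so potency remains unknown.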